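Trading Methoxy for Methyl in a Fatty Acid Receptor Agonist

This account rests on a few compounds, and the source may have more. Where it says the series, first, only, none or still open, it means among the compounds named here.

Of the compounds shown here, two built on the same core have been measured so far. Compound 1 `COc1nccc(C#Cc2ccc(CCC(=O)O)cc2)n1` was tested in an in vitro functional assay on 1321-N1 cells for agonist activity at Free fatty acid receptor 1 (Homo sapiens), read by fluorescence, spectrophotometry and calcium flux (on this read-out higher numbers stand for an effect only at larger amounts of compound and lower numbers for an effect already at smaller amounts), where compound 1 gives 9550 nM. Compound 2 `COc1cc(C#Cc2ccc(CCC(=O)O)cc2)ccn1` was run in the same way, and in this assay compound 2 gives 525 nM. Of the two numbers, compound 2 holds the lower one, and the gap to compound 1 is wide enough to lie well beyond the usual scatter. No single change connects compound 1 and compound 2, so their values simply stand side by side.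

Compound 3 `Cc1cc(C#Cc2ccc(CCC(=O)O)cc2)ccn1` is the next step from compound 2. The change is modest: methyl in place of methoxy on an aromatic carbon. For the measured compounds named here, no measured pair shows what this exchange does, so the expectation rests on compound 2 at 525 nM as the starting point. A small upward shift is expected for the step of a 1.7-fold higher number from compound 2 to compound 3 (0.23 log units; within the scatter), around the edge of the scatter rather than clearly beyond it. For compound 3 the estimate in this assay is 900 nM, with a likely range from 300 nM to 3000 nM.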

Compound 3, half-maximal effective concentration: 1120 nM
Estimate against measurement, compound 3: 1.2-fold (0.09 log units) below; the measured number falls inside the stated range.
By their numbers in this assay, from the lowest: compound 2; then compound 3; then compound 1.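

In this assay, for the compounds shown here, the exchange of methoxy for methyl gives the first direct reading at this position, the aromatic carbon next to the ring nitrogen, with a 2.1-fold higher number from compound 2 to compound 3 (0.33 log units; beyond the scatter) as the measured step. This step is modest, yet it lies beyond the usual scatter, so on this core the methoxy compound holds the lower number, and the position does respond to what is placed on it. Going by these compounds alone, the exchange takes away one heavy atom, the oxygen, along with the one hydrogen-bond acceptor counted for methoxy, but nothing measured so far explains why the number moves, and one pair cannot separate these differences from each other.

From the compounds shown here alone, only methoxy and methyl have been seen at this place, so it remains open how an amine, a chlorine atom, an ethoxy group or a longer chain would compare there. It is also unknown whether the same exchange would shift the number in a similar way on the core of compound 1, where the ring and its value differ.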